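The source may report more compounds than this note shows. Statements on the series, on what has been measured and on what is new or still open speak of the compounds shown alone.

Measured compounds:
compound 1 `OC[C@H]1O[C@@H](n2cnc3c(NCc4ccccc4Br)ncnc32)[C@H](O)[C@@H]1O` — > 166000 nM
compound 2 `COc1ccccc1CNc1ncnc2c1ncn2[C@@H]1O[C@H](CO)[C@@H](O)[C@H]1O` — > 166000 nM
compound 3 `OC[C@H]1O[C@@H](n2cnc3c(NCc4ccc(Cl)cc4Cl)ncnc32)[C@H](O)[C@@H]1O` — 127000 nM

In a functional assay on MCF cells (Homo sapiens) for antiproliferative activity, with a stated time of 72 h (a lower number here means a stronger inhibitor, a higher number a weaker inhibitor), compound 1 gives > 166000 nM, which is a limit of the assay and not a number. Compound 2 likewise gives > 166000 nM, again a limit. Within the data shown here, compound 3 gives 127000 nM, the only numerical value in the set. Compound 1 therefore stands at the limit, together with compound 2 (the limit of > 166000 nM in this assay, at which 2 of the 3 values shown sit), and nothing places it relative to compound 3 beyond what the floor allows.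

Compound 4 is `OC[C@H]1O[C@@H](n2cnc3c(NCc4ccc(F)cc4F)ncnc32)[C@H](O)[C@@H]1O`; against compound 1 the change is 2,4-difluorophenyl in place of 2-bromophenyl on a saturated chain carbon bound to a nitrogen on an aromatic ring. The closest measured step is an at least 1.3-fold lower number from compound 1 to compound 3 (0.11 log units; that floor lies within the scatter), which replaces the same 2-bromophenyl group with 2,4-dichlorophenyl, and an at least 1.3-fold lower number from compound 2 to compound 3 (0.11 log units; that floor lies within the scatter) runs the same way from another start. Both floors sit within the scatter, so no step beyond the scatter is expected for the difluoro analogue. Compound 4 is expected to give 150000 nM, with a range from 70000 nM to 400000 nM and a substantial chance of another limit. That expectation corresponds to an at least 1.1-fold lower number from compound 1 to compound 4 (0.04 log units; that floor lies within the scatter).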

Compound 4, half-maximal inhibitory concentration: > 166000 nM
Compound 4: no number, only a limit (the forecaster's own chance of this, stated with the estimate: 60%); middle value at least 1.1-fold (0.04 log units) from the limit.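

Putting 2,4-difluorophenyl in place of 2,4-dichlorophenyl, on a saturated chain carbon bound to a nitrogen on an aromatic ring, gives an at least 1.3-fold higher number from compound 3 to compound 4 (0.11 log units; that floor lies within the scatter), so this change does not separate the two compounds beyond the scatter. The steps from compound 1 and from compound 2 to compound 4 cannot be read, with a limit at both ends of each. In this assay compound 3 remains the only one of the four with a numerical value, and the series gathers at one limit: the limit of > 166000 nM in this assay, at which 3 of the 4 values shown sit.

Open, as far as these compounds go, is whether any change at this place gives a reading well clear of that limit, as all four compounds carry only halogens or methoxy on the phenyl ring. A carboxylic acid or an amine in place of those groups, or a longer chain in place of the benzyl group, would test this.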